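Swapping the Side Ring on a Weak Transporter Inhibitor

This account rests on a few compounds, and the source may have more. Where it says the series, first, only, none or still open, it means among the compounds named here.

Measured compounds:
compound 1, `[O-][S+](Cc1cccs1)C(c1ccc(Cl)cc1)c1ccc(Cl)cc1`: 7200 nM
compound 2, `Cc1scc(C[S+]([O-])C(c2ccccc2)c2ccccc2)c1C`: 284000 nM

Two sulfoxides have been tested in an assay on HEK293 cells for inhibition of sodium-dependent dopamine transporter (Homo sapiens), read by scintillation counting, with stated times of 5 min and 1 min; a lower number here means a stronger inhibitor, a higher number a weaker inhibitor. Compound 1 gives 7200 nM. Compound 2 gives 284000 nM, the higher of the two numbers, so compound 2 is the weaker inhibitor of the pair. These two compounds differ in more than one place, so their gap cannot be read as a single step.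

Compound 3 `Cc1nnc(C[S+]([O-])C(c2ccccc2)c2ccccc2)s1` has not yet been measured. It differs from compound 2 in one place: 5-methyl-1,3,4-thiadiazol-2-yl in place of 4,5-dimethylthiophen-3-yl on a saturated chain carbon bound to a sulfur. Among the compounds with values here, no single-change step among the measured compounds shows what such a swap does here, so the direction is open. The expected step is a 1.4-fold lower number from compound 2 to compound 3 (0.15 log units; within the scatter), which is estimated to stay within the usual scatter. Compound 3 is therefore estimated at 200000 nM, with a range from 50000 nM to 800000 nM.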

Compound 3, half-maximal inhibitory concentration: "not active" (no number reported)
For compound 3 the study gives words and no number, and the estimate cannot be compared.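

Within the data shown here, compound 3 is reported only as "not active", with no number, so no step from compound 2 to compound 3 can be read. Nothing at hand explains this result. The compounds shown leave open how far 5-methyl-1,3,4-thiadiazol-2-yl shifts the number.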